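Trimming a Methyl from a Sulfonamide Cytotoxicity Series

The source may hold more compounds than are shown below. What is called first, only, known or untested is meant among the compounds shown, and "the series" means these compounds.

Of the compounds shown here, two have been measured in a functional assay on HepG2 cells (Homo sapiens) for cytotoxicity, read by sulforhodamine B assay, with a stated time of 48 h; on this read-out higher numbers stand for weaker inhibition and lower numbers for stronger inhibition. Compound 1 `C/C(=N\NC(=O)CC#N)c1ccc(NS(=O)(=O)c2ccc(C)cc2)cc1` gives 26000 nM, while compound 2 `Cc1ccc(S(=O)(=O)Nc2ccc(C(=O)/C=C/c3ccc(Br)cc3)cc2)cc1` gives 30300 nM. Compound 1 has only compound 2 beside it on these numbers, and the gap between them is within the scatter, so the two cannot be told apart. Compound 3 `C/C(=N\NC(=O)CC#N)c1ccc(NS(=O)(=O)c2ccccc2)cc1` carries one change from compound 1: hydrogen in place of methyl on an aromatic carbon. Among the measured compounds shown here, no measured pair shows what this change does, so the expected step of a 1.1-fold higher number from compound 1 to compound 3 (0.03 log units; within the scatter) is none beyond the scatter, in no set direction. Compound 3 is estimated at 28000 nM, within a range from 12000 nM to 65000 nM.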

Compound 3, half-maximal inhibitory concentration: 28000 nM
Compound 3: the middle estimate sits on the measured number at the digits printed; the measured number falls inside the stated range.
By their numbers in this assay, from the lowest: compounds 1, 3 and 2 (each within the scatter of the next).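

Going from 4-methylphenyl to phenyl gives a 1.1-fold higher number from compound 1 to compound 3 (0.03 log units; within the scatter) in this assay, so this first measured pair shows that, on this read-out, the methyl at this position can give way to hydrogen with no difference beyond the scatter. No measurement available here offers a reason for this result.

Still open, on these data alone, is whether a different group at this position, such as an amine or a carboxylic acid, would give a number beyond the scatter of compound 1. As far as these compounds go, the same swap on compound 2 also remains open.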